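Two Ring Stereocentres Inverted in a Low-Bioavailability Analogue

The source may report more compounds than this note shows. Statements on the series, on what has been measured and on what is new or still open speak of the compounds shown alone.

Compound 1 `COC(=O)N[C@H](C(=O)N1CCC[C@H]1C(=O)Nc1ccc([C@H]2CC[C@H](c3ccc(NC(=O)[C@@H]4CCCN4C(=O)[C@@H](NC(=O)OC)C(C)(C)C)cc3)N2c2ccc(F)cc2)cc1)C(C)(C)C` and compound 2 `COC(=O)N[C@H](C(=O)N1CCC[C@H]1C(=O)Nc1ccc([C@@H]2CC[C@@H](c3ccc(NC(=O)[C@@H]4CCCN4C(=O)[C@@H](NC(=O)OC)[C@@H](C)OC)cc3)N2c2ccc(F)cc2)cc1)[C@@H](C)OC` were both run in an ADME assay on the whole organism for pharmacokinetics, with Rattus norvegicus as the target, at a dose of 3 mg/kg by the oral route; on this read-out higher numbers stand for higher oral bioavailability and lower numbers for lower oral bioavailability. Compound 1 gives 39%, whereas compound 2 gives 14%, the lower of the two numbers and beyond the scatter from compound 1. Within the data shown here, compound 3 `COC(=O)N[C@H](C(=O)N1CCC[C@H]1C(=O)Nc1ccc([C@H]2CC[C@H](c3ccc(NC(=O)[C@@H]4CCCN4C(=O)[C@@H](NC(=O)OC)[C@@H](C)OC)cc3)N2c2ccc(F)cc2)cc1)[C@@H](C)OC` has not been measured. the two compounds have the same atoms and bonds and differ only in configuration as drawn: 2 of 8 stereo elements differ; a stereocentre at a saturated ring carbon is drawn S in compound 2 and R in compound 3; a stereocentre at a saturated ring carbon is drawn S in compound 2 and R in compound 3 No measured pair shows how such an inversion alone shifts this read-out, so the step size is uncertain. Compound 3 is expected to give 24%, between 8% and 45%. That expectation amounts to a step of a number 10 percentage points higher from compound 2 to compound 3 (within the scatter) in this assay, upward but modest.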

Compound 3, oral bioavailability in the Rattus norvegicus assay: 15%
The estimate for compound 3 lay 9 percentage points above the measured number; low and high end bracket the measured number.
By their numbers in the Rattus norvegicus assay, from the lowest: compounds 2 and 3 (each within the scatter of the next); then compound 1.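

In the Rattus norvegicus assay, inverting the two saturated ring carbons gives a number 1 percentage points higher from compound 2 to compound 3 (within the scatter), and in a physicochemical assay for lipophilicity, read by HPLC, at pH 7.4 (on this read-out lower numbers stand for lower lipophilicity and higher numbers for higher lipophilicity), it gives no change at the digits printed from compound 2 to compound 3 (within the scatter). In the physicochemical assay compound 2 gives 3 and compound 3 gives 3. Unlike the earlier comparison, this pair isolates the configuration at these ring carbons, and neither read-out separates the two forms beyond the scatter. The step can therefore be read as a change of configuration alone: the fact that compounds 2 and 3 differ only in the configuration as drawn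

From the compounds shown here alone, whether the same inversion behaves alike in compound 1, with its different side chains, remains open. So does what an amine or a carboxylic acid on the shared core would do to oral bioavailability.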